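The source may report more compounds than this note shows. Statements on the series, on what has been measured and on what is new or still open speak of the compounds shown alone.

Measured compounds: compound 1 `Cc1nnc2nnc(N3CCCC3)nn12` with 29700 nM in a functional assay on HL-60 cells (Homo sapiens) for cytotoxicity, read by MTT assay, with a stated time of 72 h; a lower number here means a stronger inhibitor, a higher number a weaker inhibitor; compound 2 `Fc1ccc(-c2nnc3nnc(N4CCCC4)n3n2)cc1` with 4560 nM in this assay.

Compound 1 carries the highest number of the two; compound 2 sits clearly lower, beyond the scatter. Compound 3 `CC(C)(C)c1nnc2nnc(N3CCCC3)nn12` follows from compound 1 by tert-butyl in place of methyl on an aromatic carbon. Going by the values given here, no measured pair shows this change, so the size of the step rests on nothing firmer than the two numbers above. The expected step is a 2.0-fold lower number from compound 1 to compound 3 (0.30 log units; within the scatter), a shift toward a lower number that is estimated to stay close to the scatter. Compound 3 is estimated at 15000 nM, with a range from 5000 nM to 45000 nM.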

Compound 3, half-maximal inhibitory concentration: > 100000 nM
Compound 3 was reported as a limit; the forecaster's own chance of this, stated with the estimate: 5%; at least 6.6-fold (0.82 log units) between middle value and limit.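

In this assay, the aromatic carbon between two ring nitrogen atoms now shows a change that raises the number, with tert-butyl in place of methyl giving an at least 3.3-fold higher number from compound 1 to compound 3 (0.52 log units; beyond the scatter). The same position can therefore move the number both ways, with compound 2 at 4560 nM and compound 1 at 29700 nM. Compound 3 is a limit and not a number, so the step gives only a bound: the limit of > 100000 nM in this assay, at which 1 of the 3 values shown sits.

From the compounds shown here alone, whether ethyl or isopropyl at this carbon already raises the number stays open. So does the reading of an amine there.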